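The source may report more compounds than this note shows. Statements on the series, on what has been measured and on what is new or still open speak of the compounds shown alone.

Measured compounds:
Compound 1 `COc1ccc(OCC(=O)N2CCN(c3ccc(C(F)(F)F)cc3[C@@H](N)CC(C)C)CC2)cc1` gives 3800 nM in an assay on HEK293 cells for displacement of a labelled ligand from Melanocortin receptor 4 (Homo sapiens); a higher number here means a weaker inhibitor, a lower number a stronger inhibitor.
Compound 2 `CC(C)C[C@H](N)c1cc(C(F)(F)F)ccc1N1CCN(C(=O)COc2cccc(Cl)c2Cl)CC1` gives 2500 nM in this assay.
Compound 3 `CC(C)C[C@H](N)c1cc(C(F)(F)F)ccc1N1CCN(C(=O)COc2cccc3ccccc23)CC1` gives 2600 nM in this assay.

Compound 3 stands second highest of the three numbers. Its nearest neighbour is compound 2, with a 1.0-fold higher number from compound 2 to compound 3 (0.02 log units; within the scatter); the furthest is compound 1, with a 1.5-fold lower number from compound 1 to compound 3 (0.16 log units; within the scatter). The third step, a 1.5-fold lower number from compound 1 to compound 2 (0.18 log units; within the scatter), is likewise within the scatter, so the three aryl groups on the oxygen are indistinguishable on these numbers.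

The next compound is compound 4 `CC(C)C[C@H](N)c1cc(C(F)(F)F)ccc1N1CCN(C(=O)CCC(=O)N(C)C)CC1`. The change from compound 3 is (dimethylcarbamoyl)methyl in place of (naphthalen-1-yl)oxy on a saturated chain carbon bound to a carbonyl carbon. Going by the values given here, none of the measured steps bears on it directly: each of them exchanges one aryl group for another while keeping the oxygen on the saturated carbon, whereas here the (naphthalen-1-yl)oxy group leaves altogether and a (dimethylcarbamoyl)methyl group enters, a difference of a different kind. With nothing measured for such a change, the expectation rests only on its size, which is larger than any step seen so far, and the direction is open. Compound 4 is estimated at 8000 nM, with a range of 2000 nM to 30000 nM. The expected step is a 3.1-fold higher number from compound 3 to compound 4 (0.49 log units; beyond the scatter), and a wide range is carried with it.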

Compound 4, inhibition constant: > 10000 nM
Compound 4: only a limit was reported (the forecaster's own chance of this, stated with the estimate: 25%); middle value at least 1.2-fold (0.09 log units) away from the limit.
By their numbers in this assay, from the lowest: compounds 2, 3 and 1 (each within the scatter of the next). At a limit, above all of these: compound 4.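

Compound 4 is reported in this assay only as a limit, not as a number: the limit of > 10000 nM in this assay, at which 1 of the 4 values shown sits.

The three aryl groups on the oxygen could not be told apart, but this position does respond once (dimethylcarbamoyl)methyl replaces the whole aryloxy group, with an at least 3.8-fold higher number from compound 3 to compound 4 (0.58 log units; beyond the scatter), an at least 4.0-fold higher number from compound 2 to compound 4 (0.60 log units; beyond the scatter) and an at least 2.6-fold higher number from compound 1 to compound 4 (0.42 log units; beyond the scatter). From the compounds shown here alone, all three steps lie beyond the scatter and each is only a lower bound, so compound 4 is the weaker inhibitor in each pair, but the full size of the loss stays unknown; each leaving group carries an aromatic ring, while the entering group has no ring.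

Because this one exchange removes the ether oxygen and the aromatic ring and adds the dimethyl amide together, the compounds shown cannot say which of these parts accounts for the steps. Going by these compounds, it remains open whether a phenyl group on a saturated chain without the oxygen would stay close to compounds 1, 2 and 3, and how a chain ending in an amine or a carboxylic acid would behave in this assay.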